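Chalcones with two allyloxy groups tested for cytotoxicity

The source may hold more compounds than are shown below. What is called first, only, known or untested is meant among the compounds shown, and "the series" means these compounds.

Compound 1, `C=CCOc1cc(OC)c(C(=O)/C=C/c2ccc(F)cc2)c(OCC=C)c1`, gives 13800 nM in a toxicity assay on cells (Macrophage, Mus musculus, strain BALB/c) for cytotoxicity, read by MTT assay; a higher number here means a weaker inhibitor, a lower number a stronger inhibitor.
Compound 2, `C=CCOc1cc(OC)c(C(=O)/C=C/c2ccc([N+](=O)[O-])cc2)c(OCC=C)c1`, gives 13200 nM in this assay.
Compound 3, `C=CCOc1cc(OC)c(C(=O)/C=C/c2ccncc2)c(OCC=C)c1`, gives "not determined" (no result reported) in this assay, that is, no result reported.

The three measured compounds share one core and differ only in the ring attached to the double-bonded chain. Between the first two the step is a 1.0-fold lower number from compound 1 to compound 2 (0.02 log units; within the scatter), so the two measured values sit together. For compound 3 no number was obtained in this assay, so its standing among the measured compounds cannot be stated; it is known only by its structure.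

Compound 4, `C=CCOc1cc(OC)c(C(=O)/C=C/c2cccc(OC)c2)c(OCC=C)c1`, is not yet measured. It differs from compound 3 by 3-methoxyphenyl in place of pyridin-4-yl on a double-bonded chain carbon bound to a double-bonded chain carbon. Within the data shown here, no measured step bears directly on this change, since compound 3 itself carries no value. Among the measured compounds shown here, the one measured step, between compounds 1 and 2, lay within the scatter although it exchanged groups on the aromatic ring, and both of those compounds fall close to each other. On that basis a value near the two measured ones is expected for compound 4 in this assay, with no clear direction beyond the scatter. Compound 4 is therefore estimated at 13000 nM, in the range 5000 nM to 40000 nM.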

Compound 4, half-maximal inhibitory concentration: 13100 nM
Compound 4: middle estimate off by 1.0-fold (0.00 log units), on the low side, and the stated range covers the measured number.
By their numbers in this assay, from the lowest: compounds 4, 2 and 1 (each within the scatter of the next).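

In this assay, 3-methoxyphenyl on a double-bonded chain carbon bound to a double-bonded chain carbon, in place of 4-nitrophenyl, gives a 1.0-fold lower number from compound 2 to compound 4 (0.00 log units; within the scatter) and, in place of 4-fluorophenyl, gives a 1.1-fold lower number from compound 1 to compound 4 (0.02 log units; within the scatter). Among these compounds, the earlier step compared only two groups named at the 4-position of a phenyl ring, whereas compound 4 shows that a methoxy group named at the 3-position also leaves the number within the scatter of both, so compounds 1, 2 and 4 form one level with none going against it, while compound 3 has no number and no step to it can be read. Nothing measured here offers an explanation for why these three numbers sit together.

On these data alone, whether this level would persist with an amine or a carboxylic acid on the phenyl ring, or with a longer chain in place of the methoxy group of compound 4, remains open. Also open is whether the shared level depends on the two allyloxy groups of the core, since all the compounds shown carry them.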